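The source may hold more compounds than are shown below. What is called first, only, known or untested is meant among the compounds shown, and "the series" means these compounds.

Measured compounds in a functional assay on SW480 cells (Homo sapiens) for cytotoxicity, read by MTT assay, with a stated time of 4 days; on this read-out higher numbers stand for weaker inhibition and lower numbers for stronger inhibition:
Compound 1 `Cc1c(O)ccc2c1[C@H](Cn1cc(-c3ccccc3)nn1)[C@@]13CC(=O)[C@@](C)(CC[C@@H]21)C3` is reported only as a limit of the assay, > 20000 nM.
Compound 2 `C=C1C[C@]23C[C@@]1(O)CC[C@@H]2c1cccc(C)c1[C@@H]3Cn1cc(-c2ccc(OC)cc2)nn1` is likewise reported only as a limit, > 20000 nM.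
Compound 3 `C=C1C(=O)[C@]23C[C@@]1(O)CC[C@H]2c1ccc(O)c(C)c1[C@@H]3Cn1cc(-c2ccc(C(F)(F)F)cc2)nn1` gives 370 nM.

Compound 2 therefore stands at the weak end of what is shown, at the limit of > 20000 nM in this assay, at which 2 of the 3 values shown sit, with no number of its own. Compound 4 `C=C1C[C@]23C[C@@]1(O)CC[C@@H]2c1cccc(C)c1[C@@H]3Cn1cc(-c2ccc(Cl)cc2)nn1` differs from it in one place: chloro in place of methoxy on an aromatic carbon. Within the data shown here, no measured pair shows such a change in this assay, so the step can only be expected, not read off. From compound 2 to compound 4 the expected step is a step that the limit leaves unreadable from compound 2 to compound 4, nothing beyond the scatter. For compound 4 the estimate is 25000 nM, with a range from 5000 nM to 100000 nM.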

Compound 4, half-maximal inhibitory concentration: > 20000 nM
Compound 4: no number, only a limit; the forecaster's own chance of this, stated with the estimate: 70%; the middle value does not contradict the limit.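

In this assay compound 4 gives > 20000 nM, a limit and not a number. Compound 2 also gives only a limit, > 20000 nM, so no step can be read between compound 2 and compound 4. The compounds shown leave open whether chloro and methoxy differ at all in this assay.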